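This account rests on a few compounds, and the source may have more. Where it says the series, first, only, none or still open, it means among the compounds named here.

Measured so far in an ADME assay on microsomes from liver (Homo sapiens) for metabolic stability, with a stated time of 10 min; on this read-out lower numbers stand for a less stable compound and higher numbers for a more stable compound:
Compound 1 `c1ccc2oc(-c3cn4nc(C5CC5)sc4n3)cc2c1` gives 62%.
Compound 2 `COc1nn2cc(-c3cc4ccccc4o3)nc2s1` gives 80%.
Compound 3 `COc1cc(OCc2cccc(CCc3ccccc3)c2)c2cc(-c3cn4nc(OC)sc4n3)oc2c1` gives 99%.

Compound 3 stands highest of the three numbers; its nearest neighbour is compound 2 and its furthest is compound 1, and both gaps lie beyond the scatter. Going by the values given here, the only measured step, methoxy in place of cyclopropyl on an aromatic carbon, gave a number 18 percentage points higher from compound 1 to compound 2 (beyond the scatter).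

Compound 4 `COc1cc(OCc2cccc(Sc3ccccc3)c2)c2cc(-c3cn4nc(OC)sc4n3)oc2c1` differs from compound 3 in one place: phenylsulfanyl in place of phenethyl on an aromatic carbon. Among the compounds with values here, no measured step bears on this change; the step from compound 1 to compound 2 concerns another group at another place and says nothing about phenethyl or phenylsulfanyl. Since compound 3 already sits near the top of the scale in this assay, whatever movement is expected for compound 4 would be downward or none beyond the scatter. Compound 4 is therefore estimated at 92%, between 75% and 100%. This estimate means an expected step of a number 7 percentage points lower from compound 3 to compound 4 (within the scatter), within the scatter.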

Compound 4, percent of the compound remaining: 80%
Estimate against measurement, compound 4: 12 percentage points above; the range from low to high includes it.
By their numbers in this assay, from the lowest: compound 1; then compounds 2 and 4 (each within the scatter of the next); then compound 3.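

Going by these compounds alone, at this place, on an aromatic carbon of a six-membered aromatic ring of carbon only and meta to a large group, the earlier compounds showed nothing, but in this assay the group proves able to move the read-out: phenylsulfanyl in place of phenethyl gives a number 19 percentage points lower from compound 3 to compound 4 (beyond the scatter) on the otherwise unchanged core. The change is small in count, since both groups carry one six-membered aromatic ring, while phenylsulfanyl brings sulfur and one hydrogen-bond acceptor where phenethyl has eight carbons and no acceptor. Nothing available explains why the number falls, and the step alone cannot separate the sulfur from the shorter link.

As far as these compounds go, whether a phenoxy group, with oxygen as the link, or a benzyl group, with a single carbon as the link, would stand nearer compound 3 or compound 4 stays open. So does whether a sulfonyl link or an amine at this place would move the number at all.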